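The source may report more compounds than this note shows. Statements on the series, on what has been measured and on what is new or still open speak of the compounds shown alone.

Measured compounds:
compound 1 `COc1cc2c(cc1OC)C(CC(=O)O)CC2` — 24%
compound 2 `COc1cc2c(cc1OC)C(CC(=O)Nc1ccc(Cl)cc1)CC2` — 63%

In a functional assay on the whole organism (strain Wistar) for inhibition, with Rattus norvegicus as the target, read by paw edema, with a stated time of 2 h, at a dose of 100 mg/kg (on this read-out lower numbers stand for less inhibition and higher numbers for more inhibition at the one dose given (going by the name of the read-out)), compound 1 gives 24%, and compound 2 gives 63%. For the measured compounds named here, the single measured step, a number 39 percentage points higher from compound 1 to compound 2 (beyond the scatter), shows that replacing the hydroxy on the carbonyl carbon with the (4-chlorophenyl)amino group raises the read-out well beyond the scatter. Going by the values given here, compound 2 therefore stands highest of the two numbers known so far, with compound 1 as its only neighbour, far below it.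

Compound 3 `COc1cc2c(cc1OC)C(CC(=O)Nc1ccccc1C)CC2` differs from compound 2 by 2-methylphenyl in place of 4-chlorophenyl on an amide-type nitrogen. Among the compounds with values here, no measured step bears directly on this change: the one step known concerns the presence of the amide-type nitrogen and its aryl group, not an exchange of one aryl group for another. The amide and the shared core are kept, so the part that carried the large step from compound 1 to compound 2 stays in place. The step of a number 11 percentage points lower from compound 2 to compound 3 (beyond the scatter) is therefore expected to be small, possibly none beyond the scatter, with some chance of a modest drop. For compound 3 the estimate in this assay is 52%, in a range from 28% to 70%.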

Compound 3, a percentage reported as inhibition, in the whole organism at one dose (the size of the read-out at that dose, not a potency): 18%
Compound 3: middle estimate off by 34 percentage points, on the high side, and the stated range ends above it.
By their numbers in this assay, from the lowest: compounds 3 and 1 (each within the scatter of the next); then compound 2.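

In this assay the exchange of 4-chlorophenyl for 2-methylphenyl on the amide-type nitrogen gives a number 45 percentage points lower from compound 2 to compound 3 (beyond the scatter) and removes the whole gain of a number 39 percentage points higher from compound 1 to compound 2 (beyond the scatter), so the amide alone does not carry that gain and the aryl group on this nitrogen decides the read-out among the compounds shown. With (2-methylphenyl)amino in place of hydroxy on the carbonyl carbon, the result is a number 6 percentage points lower from compound 1 to compound 3 (within the scatter), which leaves this amide and the acid indistinguishable at this one dose. No available data explain why the two aryl groups part so widely.

The exchange removes chlorine and brings in methyl at another ring position in a single change: phenyl, 2-chlorophenyl and 4-methylphenyl on the same nitrogen would show which part of it matters. Also open, going by these compounds, is how a benzyl group on that nitrogen, or a longer chain joining the shared core to the carbonyl, would read in this assay at this dose.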